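Working notes: aryl amide to oxanyl amide, cytotoxicity

The source may hold more compounds than are shown below. What is called first, only, known or untested is meant among the compounds shown, and "the series" means these compounds.

Compound 1 `Cn1c(-c2cccc(Cl)c2)cnc1NC(=O)c1ccc(F)cc1` in a toxicity assay on THP-1 cells (Homo sapiens) for inhibition (a higher number here means that more compound is tolerated, a lower number that less compound is tolerated), sits at a limit, > 50000 nM.
Compound 2 `Cn1c(-c2cccc([N+](=O)[O-])c2)cnc1NC(=O)c1ccc(F)cc1` in this assay also sits at a limit, > 50000 nM.
Compound 3 `COc1ccc(-c2cnc(NC(=O)c3cccc(OC)c3)n2C)cc1` in this assay sits at a limit, > 100000 nM.

No value in this set is a number. The step that the two limits leave unreadable from compound 1 to compound 2 cannot be read because both ends are limits (the limit of > 50000 nM in this assay, at which 2 of the 3 values shown sit). Compound 3 stands at the limit of > 100000 nM in this assay, at which 1 of the 3 values shown sits, the higher of the two limits seen here.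

Compound 4 `COc1ccc(-c2cnc(NC(=O)C3CCOCC3)n2C)cc1` differs from compound 3 by oxan-4-yl in place of 3-methoxyphenyl on a carbonyl carbon. For the measured compounds named here, no measured step bears on this change; the only computed step is unreadable. Going by the values given here, with every compound so far tolerated up to its limit, no step beyond the scatter is expected. Compound 4 is expected to give 100000 nM, between 30000 nM and 300000 nM. The expected step is a number no higher from compound 3 to compound 4 (the limit leaves the size open), most likely again reported only as a limit.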

Compound 4, half-maximal cytotoxic concentration: > 100000 nM
Compound 4: a limit, no number; the forecaster's own chance of this, stated with the estimate: 85%; the middle value sits exactly at the limit.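

The step from compound 3 to compound 4 cannot be read because both ends sit at the same limit: the limit of > 100000 nM in this assay, at which 2 of the 4 values shown sit.

The compounds shown leave open at what concentration any of them becomes toxic in this assay.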